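Shortening the chain on the carbonyl carbon

This account rests on a few compounds, and the source may have more. Where it says the series, first, only, none or still open, it means among the compounds named here.

Compound 1 `COc1cc(C(=O)O)ccc1OCCCCOc1ccc(C(=O)CC(C)C)c(O)c1C`: 85.7%
Compound 2 `COc1cc(C(=O)O)ccc1OCCCCOc1ccc(C(=O)CC(C)(C)C)c(O)c1C`: 98.6%

In an assay on HEK293 cells for positive allosteric modulation of metabotropic glutamate receptor 2 (Rattus norvegicus), read by thallium flux, with a stated time of 2.5 min (on this read-out lower numbers stand for smaller maximal responses and higher numbers for larger maximal responses), compound 2 gives 98.6%, the higher of the two numbers measured, while compound 1 gives 85.7%. Going by the values given here, the one measured step, a number 12.9 percentage points higher from compound 1 to compound 2 (beyond the scatter), came with a methyl added on the chain. Compound 3 `COc1cc(C(=O)O)ccc1OCCCCOc1ccc(C(C)=O)c(O)c1C` differs from compound 2 by hydrogen in place of tert-butyl on a saturated chain carbon bound to a carbonyl carbon. This removes far more than the earlier step added, so a fall is expected, larger than that step, because a number 12.9 percentage points higher from compound 1 to compound 2 (beyond the scatter) went upward as the chain grew. The expected step is a number 28.6 percentage points lower from compound 2 to compound 3 (beyond the scatter). Compound 3 is therefore estimated at 70%, between 50% and 90%.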

Compound 3, largest response reached (reported as percent of maximum), in percent of the reference or control that the assay uses: 86.3%
Estimate against measurement, compound 3: 16.3 percentage points below; the range from low to high includes it.
By their numbers in this assay, from the lowest: compounds 1 and 3 (each within the scatter of the next); then compound 2.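

Replacing tert-butyl with hydrogen on the saturated chain carbon bound to a carbonyl carbon gives a number 12.3 percentage points lower from compound 2 to compound 3 (beyond the scatter), while replacing isopropyl with hydrogen at the same place gives a number 0.6 percentage points higher from compound 1 to compound 3 (within the scatter). The response therefore does not follow the size of the group across these compounds: the acetyl compound 3 cannot be told apart from compound 1, and only compound 2, with its neopentyl chain, stands apart. Nothing measured here explains this. Going by these compounds, whether a longer chain, a phenyl ring or an amine at this place would match compound 2 remains open.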